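This account rests on a few compounds, and the source may have more. Where it says the series, first, only, none or still open, it means among the compounds named here.

Three compounds have been measured in a functional assay on HEK293 cells for antagonist activity at thromboxane A2 receptor (Homo sapiens), read by fluorescence and calcium flux; on this read-out higher numbers stand for weaker inhibition and lower numbers for stronger inhibition:
compound 1 `CC(C)NC(=O)NS(=O)(=O)c1cc(C#N)ccc1Oc1ccc(Cl)cc1` gives 8490 nM;
compound 2 `CC(C)NC(=O)NS(=O)(=O)c1cc(C#N)ccc1Oc1ccc(Br)cc1` gives 9130 nM;
compound 3 `CC(C)(C)NC(=O)NS(=O)(=O)c1cc(C#N)ccc1Oc1ccc(Br)cc1` gives 5310 nM.

Compound 2 sits at one end of these three numbers, yet both of its steps to the others lie within the scatter: a 1.1-fold higher number from compound 1 to compound 2 (0.03 log units; within the scatter) and a 1.7-fold lower number from compound 2 to compound 3 (0.24 log units; within the scatter). Compound 4 `CC(C)NC(=O)NS(=O)(=O)c1cc(C#N)ccc1Nc1ccc(F)cc1` has not yet been measured. It differs from compound 2 in one place: (4-fluorophenyl)amino in place of 4-bromophenoxy on an aromatic carbon. Neither measured step touches this part of the molecule in the same way. Exchanging one halogen for another on that ring, a 1.1-fold higher number from compound 1 to compound 2 (0.03 log units; within the scatter), changed little, and the change at the other end of the molecule, a 1.7-fold lower number from compound 2 to compound 3 (0.24 log units; within the scatter), also stayed within the scatter. Nothing measured here speaks to replacing the oxygen link with an amino link. Within the data shown here, with no measured step pointing either way, the number for compound 4 is expected to stay near that of compound 2, so the expected step is a 1.0-fold lower number from compound 2 to compound 4 (0.01 log units; within the scatter), with a wide range. Compound 4 is estimated at 9000 nM, between 2500 nM and 30000 nM in this assay.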

Compound 4, half-maximal inhibitory concentration: 7830 nM
Compound 4: the middle estimate sits 1.1-fold (0.06 log units) above what was measured; measured number inside the range.
By their numbers in this assay, from the lowest: compounds 3, 4, 1 and 2 (each within the scatter of the next).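

In this assay, replacing the whole aryl ether arm gives a 1.2-fold lower number from compound 2 to compound 4 (0.07 log units; within the scatter) with 4-bromophenoxy leaving and a 1.1-fold lower number from compound 1 to compound 4 (0.04 log units; within the scatter) with 4-chlorophenoxy leaving, so neither swap takes the number beyond the scatter. This position, para to a cyano group, therefore tolerates (4-fluorophenyl)amino, even though it brings a hydrogen-bond donor that 4-bromophenoxy lacks. The linking atom and the halogen change together in these steps, so neither can be judged alone.

No measurement shown here explains this result. Going by these compounds, what remains open is how 4-fluorophenoxy or (4-bromophenyl)amino would read, as each would separate the link from the halogen, and whether a larger change at this position, such as a carboxylic acid on the outer ring, would give a step beyond the scatter.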